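Cytotoxicity limits in a fused-ring sulfonamide series

The compounds below may be only part of what the source reports. "The series", "measured", "known", "first", "only" and "open" are said of these compounds alone.

Compound 1, `CS(=O)(=O)Nc1ccc2c(c1)S(=O)(=O)N=C(C1=C(O)C3CCCC3N(CCC3CC3)C1=O)N2`: in an ADME assay on Huh-7 cells (Homo sapiens) for cytotoxicity, with a stated time of 72 h (on this read-out higher numbers stand for lower toxicity in this test and lower numbers for higher toxicity in this test), compound 1 gives > 33000 nM, a limit of the assay.
Compound 2, `CN1C(=O)C(C2=NS(=O)(=O)c3cc(NS(C)(=O)=O)ccc3N2)=C(O)C2CCCC21`: in this assay compound 2 gives "not determined" (no result reported).
Compound 3, `CCN1C(=O)C(C2=NS(=O)(=O)c3cc(NS(C)(=O)=O)ccc3N2)=C(O)C2CCCC21`: in this assay compound 3 gives > 33000 nM, again a limit.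

Compound 3 therefore stands at the ceiling of what this assay reports, and no single number is known for it. Among the compounds with values here, the only step between measured compounds, a step that the two limits leave unreadable from compound 1 to compound 3, cannot be sized because of the limit of > 33000 nM in this assay, at which 2 of the 3 values shown sit. Compound 4, `CS(=O)(=O)Nc1ccc2c(c1)S(=O)(=O)N=C(C1=C(O)C3CCCC3N(Cc3ccccn3)C1=O)N2`, differs from compound 3 by pyridin-2-yl in place of methyl on a saturated chain carbon bound to an amide-type nitrogen in a ring. Within the data shown here, no measured step bears on this change, and the data give no direction for it. Compound 4 is expected to remain at the limit, so the step of a number no higher from compound 3 to compound 4 (the limit leaves the size open) is estimated as none beyond the scatter. Compound 4 is estimated at 33000 nM, between 12000 nM and 80000 nM.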

Compound 4, half-maximal cytotoxic concentration: > 33000 nM
Compound 4 ended at the assay's limit; the forecaster's own chance of this, stated with the estimate: 70%; the middle value sits exactly at the limit.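

Compound 4, like compound 1 and compound 3, gives only a limit, so no step among them can be read: the limit of > 33000 nM in this assay, at which 3 of the 4 values shown sit.

The compounds shown leave open whether any group at this place on the amide-type nitrogen's chain changes the read-out in this assay.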